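The source may hold more compounds than are shown below. What is called first, only, known or untested is meant among the compounds shown, and "the series" means these compounds.

Two compounds of this series carry numbers in a functional assay on CHO cells for agonist activity at adenosine receptor A2b (Homo sapiens), read by scintillation counting and cAMP accumulation, with a stated time of 150 min, in the presence of a further agent that is not named here (a lower number here means a stronger inhibitor, a higher number a weaker inhibitor), so far. Compound 1 `COc1cccc(CNc2nc(N)c3nc(-c4ccc(C)o4)sc3n2)c1` gives 120 nM there. Compound 2 `Nc1nc(NCc2ccncc2)nc2sc(-c3ccco3)nc12` gives 33 nM and so holds the lowest of the two numbers; compound 1 sits above it by a gap that is beyond the scatter. Among the measured compounds shown here, compound 1 and compound 2 differ in more than one place, so no single step is isolated between them; their two values show only that compound 2 comes out as the stronger of the pair.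

Compound 3 `Nc1nc(NCc2cnccn2)nc2sc(-c3ccco3)nc12` is not yet measured. It departs from compound 2 in one place: pyrazin-2-yl in place of pyridin-4-yl on a saturated chain carbon bound to a nitrogen on an aromatic ring. For the measured compounds named here, no measured pair isolates this change, so its size cannot be read from any step; what is known is that a ring on this chain carbon is present in both compound 2 and compound 1, and compound 1 with a different ring there and a second change still gives 120 nM.

The step expected from compound 2 to compound 3, a 1.5-fold higher number from compound 2 to compound 3 (0.18 log units; within the scatter), is small, within the scatter or barely beyond it, toward a higher number if anything. For compound 3 the estimated value in this assay is 50 nM, with a range from 15 nM to 160 nM.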

Compound 3, half-maximal inhibitory concentration: 13.2 nM
Compound 3: middle estimate off by 3.8-fold (0.58 log units), on the high side; the measured number lies below the stated range.
By their numbers in this assay, from the lowest: compound 3; then compound 2; then compound 1.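

In this assay, the ring on the saturated chain carbon bound to a nitrogen on an aromatic ring now has a step of its own: pyrazin-2-yl in place of pyridin-4-yl gives a 2.5-fold lower number from compound 2 to compound 3 (0.40 log units; beyond the scatter), a modest move. This position therefore responds to an exchange between two six-membered aromatic rings with the same number of heavy atoms, where the entering ring has 2 hetero atoms and 2 hydrogen-bond acceptors and the leaving ring has 1 of each; the earlier pair could not show this, as compound 1 and compound 2 differ in more than one place. No measured evidence bears on the origin of the step.

With a single exchange at this position, the step cannot be assigned to the second ring nitrogen rather than to the different ring attachment, and pyridin-2-yl or pyrimidin-2-yl on the same chain carbon would be needed to separate the two. Also open, from the compounds shown here alone, is whether the step holds on a longer chain in place of the methylene link, or with another ring, such as phenyl, at this position.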